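Thiophene for furan: a swap expected to change little

The source may hold more compounds than are shown below. What is called first, only, known or untested is meant among the compounds shown, and "the series" means these compounds.

Compound 2 `c1coc(-c2ccnc(-c3ccco3)c2)c1` and compound 1 `c1coc(-c2ccnc(-c3cccs3)c2)c1` share one core. In a functional assay on SK-MEL-2 cells (Homo sapiens) for antiproliferative activity (on this read-out lower numbers stand for an effect already at smaller amounts and higher numbers for an effect only at larger amounts of compound), compound 2 gives 118000 nM, and compound 1 gives 118000 nM; the step of no change at the digits printed from compound 2 to compound 1 (within the scatter) follows from thiophen-2-yl in place of furan-2-yl on an aromatic carbon. Compound 3 `c1coc(-c2cc(-c3cccs3)nc(-c3cccs3)c2)c1` carries a further group, and in this assay compound 3 gives 118000 nM, so that no change at the digits printed from compound 1 to compound 3 (within the scatter). How the core of compound 3 differs from that of compound 2 is not broken down here. Compound 4 `c1csc(-c2cc(-c3cccs3)nc(-c3cccs3)c2)c1` has not been measured. It arises from compound 3 by thiophen-2-yl in place of furan-2-yl on an aromatic carbon, the same kind of change as from compound 2 to compound 1, though the place differs: there the group sat next to the ring nitrogen and meta to a furan-2-yl group, here it sits opposite the ring nitrogen and meta to two thiophen-2-yl groups. The expectation rests on compound 2 and compound 1, whose step no change at the digits printed from compound 2 to compound 1 (within the scatter) showed nothing, and on the step of no change at the digits printed from compound 1 to compound 3 (within the scatter). Compound 4 is therefore expected to give 118000 nM in this assay, between 60000 nM and 118000 nM. This means an expected step of no change at the digits printed from compound 3 to compound 4 (within the scatter).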

Compound 4, half-maximal effective concentration: 118000 nM
Compound 4: middle estimate and measured number agree at the digits printed; the range from low to high includes it.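

Thiophen-2-yl in place of furan-2-yl, here opposite the ring nitrogen, gives no change at the digits printed from compound 3 to compound 4 (within the scatter) in this assay. Set beside the earlier step, the change carries across both cores: the same change on two cores in this assay, no change at the digits printed (within the scatter) from compound 2 to compound 1 and no change at the digits printed (within the scatter) from compound 3 to compound 4, 1.0-fold (0.00 log units) apart, within the scatter of two such steps This shows only that the swap leaves the read-out unmoved on these two cores; since all four compounds print the same number, it does not show how the swap would behave on a core with an effect at smaller amounts.

The compounds shown leave open what an amine, a carboxylic acid or a longer chain would do in place of these five-membered aromatic rings. They also leave open whether any replacement on this core moves the value at all.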